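Methyl for chloro on the amide aromatic ring

The compounds below may be only part of what the source reports. "The series", "measured", "known", "first", "only" and "open" are said of these compounds alone.

Compound 1 `O=C(CCc1cccc2c1B(O)OC2)Nc1ccccc1`: 200 nM
Compound 2 `O=C(CCc1cccc2c1B(O)OC2)NCc1ccccc1`: > 100000 nM
Compound 3 `O=C(CCc1cccc2c1B(O)OC2)Nc1ccc(Cl)cc1`: 5000 nM
Compound 4 `Cc1ccc(NC(=O)CCc2cccc3c2B(O)OC3)cc1`: not yet measured

In a functional assay on SK-OV-3 cells (Homo sapiens) for antiproliferative activity, read by MTT assay, with a stated time of 72 h (on this read-out higher numbers stand for weaker inhibition and lower numbers for stronger inhibition), compound 3 gives 5000 nM, the higher of the two actual numbers in the series. Compound 2 stands at > 100000 nM, which is a limit and not a number.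

Compound 4 carries methyl in place of chloro on an aromatic carbon. The measured step that bears most directly on this place is a 25-fold higher number from compound 1 to compound 3 (1.40 log units; beyond the scatter), where chloro took the place of hydrogen. The steps of an at least 500-fold higher number from compound 1 to compound 2 (2.69 log units; beyond the scatter) and an at least 20-fold lower number from compound 2 to compound 3 (1.30 log units; beyond the scatter) were also large, but they change the group on the amide-type nitrogen. Going by the values given here, no measured compound carries methyl here, so the expectation is loose. A moderate move towards compound 1 at 200 nM is expected, giving a 2.5-fold lower number from compound 3 to compound 4 (0.40 log units; beyond the scatter). The estimate for compound 4 is 2000 nM, with an expected range of 400 nM to 10000 nM.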

Compound 4, half-maximal inhibitory concentration: 860 nM
Compound 4: the middle estimate sits 2.3-fold (0.37 log units) above what was measured; measured number inside the range.
By their numbers in this assay, from the lowest: compound 1; then compound 4; then compound 3. At a limit, above all of these: compound 2.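

In this assay, the aromatic carbon para to a large group proves sensitive to which group sits there, not merely to whether hydrogen is replaced: methyl in place of chloro gives a 5.8-fold lower number from compound 3 to compound 4 (0.76 log units; beyond the scatter), while methyl in place of hydrogen still gives a 4.3-fold higher number from compound 1 to compound 4 (0.63 log units; beyond the scatter). Both substituted compounds thus stand above compound 1, with methyl costing less than chloro. Against the benzyl amide, the 4-methylphenyl amide gives an at least 110-fold lower number from compound 2 to compound 4 (2.06 log units; beyond the scatter), though the value of compound 2 behind that step is a limit and not a number: the limit of > 100000 nM in this assay, at which 1 of the 4 values shown sits.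

Going by these compounds, it remains open whether any group at this place can reach or pass compound 1 at 200 nM. A methoxy group, an amine or a carboxylic acid here would extend the comparison beyond hydrogen, methyl and chloro.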